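The compounds below may be only part of what the source reports. "The series", "measured", "known", "first", "only" and "open" are said of these compounds alone.

Compounds measured in an ADME assay on microsomes from liver (Homo sapiens) for metabolic stability, read by LC-MS, using NADPH, with a stated time of 10 min, tested at 0.1 uM; on this read-out higher numbers stand for fast clearance and lower numbers for slow clearance:
compound 1, `COc1ccc(F)cc1N1C(=O)CSC1c1cccc(C(=O)NCCCCn2cccn2)c1`, 421 mL.min-1.g-1;
compound 2, `O=C(NCCCCc1ccccc1)c1cccc(C2SCC(=O)N2c2cccc(F)c2)c1`, 1840 mL.min-1.g-1;
compound 3, `COc1ccccc1N1C(=O)CSC1c1cc(F)cc(C(=O)NCCCCc2ccccc2)c1`, 2080 mL.min-1.g-1.

Compound 2 stands second highest of the three numbers. Its nearest neighbour is compound 3, whose value lies within the scatter of it, so the two cannot be told apart. Compound 1 sits furthest away, with a clearly lower number that lies beyond the scatter.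

Compound 4, `O=C(NCCCCc1ccccc1)c1cccc(C2SCC(=O)N2c2ccc(C3CC3)cc2)c1`, is not yet measured. It differs from compound 2 in one place: 4-cyclopropylphenyl in place of 3-fluorophenyl on an amide-type nitrogen in a ring. For the measured compounds named here, no step between measured compounds isolates this change, so its effect is unknown. Compound 4 is expected to remain close to compound 2 in this assay, with no step beyond the scatter, a 1.1-fold higher number from compound 2 to compound 4 (0.04 log units; within the scatter). The estimate for compound 4 is 2000 mL.min-1.g-1, expected between 900 mL.min-1.g-1 and 4500 mL.min-1.g-1.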

Compound 4, intrinsic clearance in microsomes: 811 mL.min-1.g-1
Compound 4: the middle estimate sits 2.5-fold (0.39 log units) above what was measured; measured number below the stated range.
By their numbers in this assay, from the lowest: compounds 1 and 4 (each within the scatter of the next); then compounds 2 and 3 (each within the scatter of the next).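

In this assay the group on the amide-type nitrogen in a ring proves able to shift clearance: 4-cyclopropylphenyl in place of 3-fluorophenyl gives a 2.3-fold lower number from compound 2 to compound 4 (0.36 log units; beyond the scatter) and is a modest step beyond the scatter. For the compounds shown here, this is the first change at this position that can be read on its own, and its direction is towards slower clearance. Nothing at hand gives a cause for the step.

Going by these compounds alone, the single step swaps the fluorine and the cyclopropyl together, so the part each plays stays unresolved. From the compounds shown here alone, how an unsubstituted phenyl or a phenyl bearing an amine would behave at this position remains open.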